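A few compounds are considered here, and "the series" means these few. Any claim that something is new, unique, unknown or untested is made for them only; others in the source may bear on it.

Measured in a functional assay on A-375 cells (Homo sapiens) for activation, with a stated time of 3 days; a higher number here means that more compound is needed for the effect, a lower number that less compound is needed:

Compound 1 `O=C(Nc1ccc(-c2cscn2)cc1)C1CN(Cc2ccc(F)c(F)c2)C1`: > 20000 nM, a limit and not a number
Compound 2 `O=C(Nc1ccc(-c2cscn2)cc1)C1CCCN(Cc2cccc(F)c2)C1`: compound 2 gives 5000 nM

The result of compound 1 is only a limit: the limit of > 20000 nM in this assay, at which 1 of the 2 values shown sits. Among the measured compounds shown here, that leaves compound 2 with the only true number in the set, so there is no second number to rank it against.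

The next molecule, compound 3 `O=C(Nc1ccc(-c2cscn2)cc1)C1CCCN(Cc2ccc(Cl)c(Cl)c2)C1`, keeps the rest of compound 2 and alters one group: 3,4-dichlorophenyl in place of 3-fluorophenyl on a saturated chain carbon bound to an amine nitrogen in a ring. In plain terms, 3,4-dichlorophenyl stands in place of 3-fluorophenyl on a saturated chain carbon bound to an amine nitrogen in a ring, so 3-fluorobenzyl becomes 3,4-dichlorobenzyl.

For the measured compounds named here, no two measured compounds differ in just one place, so nothing yet shows directly what a swap like this does. The starting point is therefore compound 2 at 5000 nM. From there, a modest move towards a lower number in this assay is expected, not much beyond the usual scatter, and a move the other way cannot be ruled out. The expected step is a 2.0-fold lower number from compound 2 to compound 3 (0.30 log units; within the scatter). The estimated value for compound 3 is 2500 nM, expected to lie between 600 nM and 10000 nM.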

Compound 3, half-maximal effective concentration: 3000 nM
Compound 3: middle estimate off by 1.2-fold (0.08 log units), on the low side, and the stated range covers the measured number.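

In this assay, among the compounds shown here, replacing 3-fluorobenzyl with 3,4-dichlorobenzyl gives a 1.7-fold lower number from compound 2 to compound 3 (0.22 log units; within the scatter), the first direct reading of a swap at this place, on a saturated chain carbon bound to an amine nitrogen in a ring. Since that step lies within the usual scatter, the two compounds cannot be told apart, and for this pair, two chlorine atoms on the phenyl ring in place of one fluorine leave the result indistinguishable from that of the fluorinated compound. Nothing measured here explains why the result falls as it does.

Still open, going by these compounds, is whether any other group at this place, such as a plain benzyl, a 3-chlorobenzyl, a pyridine ring, a carboxylic acid or a longer chain to the ring nitrogen, would move the number by more than the scatter. Compound 1 gives only a limit, > 20000 nM, and it differs from each of the other two in more than one place, so it adds no readable step on what this position tolerates.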